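Triazole-linked flavanone analogues and nitric oxide inhibition

The source may hold more compounds than are shown below. What is called first, only, known or untested is meant among the compounds shown, and "the series" means these compounds.

Measured compounds:
Compound 1 `COc1ccc([C@@H]2CC(=O)c3c(O)cc(OCc4cn(CC5CC5)nn4)cc3O2)cc1O` — 11900 nM
Compound 2 `COc1ccc([C@@H]2CC(=O)c3c(O)cc(OCc4cn(Cc5ccccc5Cl)nn4)cc3O2)cc1O` — 6140 nM

Both compounds were tested in a functional assay on RAW264.7 cells (Mus musculus) for inhibition, read by Griess assay, with stated times of 2 h and 24 h; on this read-out higher numbers stand for weaker inhibition and lower numbers for stronger inhibition. Compound 2 holds the lowest of the two numbers, with compound 1 the nearest, yet the step from compound 1 to compound 2, a 1.9-fold lower number from compound 1 to compound 2 (0.29 log units; within the scatter), falls within the scatter, so the two cannot be set apart in this assay.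

Compound 3 `COc1ccc([C@@H]2CC(=O)c3c(O)cc(OCc4cn(Cc5cccc(C#N)c5)nn4)cc3O2)cc1O` is the next member of the series and has not been measured. It differs from compound 2 in one place: 3-cyanophenyl in place of 2-chlorophenyl on a saturated chain carbon bound to an aromatic nitrogen. Within the data shown here, the only measured step that bears on this position is the one from compound 1 to compound 2, where a cyclopropyl became a 2-chlorophenyl with a change that stayed within the scatter. Among the measured compounds shown here, that is the sole guide available; there is no measured pair in which one substituted phenyl is swapped for another.

On this basis the expected step from compound 2 to compound 3 in this assay is a 1.1-fold higher number from compound 2 to compound 3 (0.02 log units; within the scatter), which is no step beyond the scatter. Compound 3 is therefore estimated at 6500 nM, with a range from 2500 nM to 17000 nM.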

Compound 3, half-maximal inhibitory concentration: 18000 nM
The estimate for compound 3 lay 2.8-fold (0.44 log units) below the measured number; measured number outside the range, above it.
By their numbers in this assay, from the lowest: compounds 2, 1 and 3 (each within the scatter of the next, the first and the last beyond it).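

In this assay, among these compounds, the saturated chain carbon bound to an aromatic nitrogen proved sensitive to which substituted phenyl it carries: going from 2-chlorobenzyl to 3-cyanobenzyl gave a 2.9-fold higher number from compound 2 to compound 3 (0.47 log units; beyond the scatter) and so produced the first step at this position to pass beyond the scatter, though only a modest one. Replacing cyclopropyl with 3-cyanophenyl gave a 1.5-fold higher number from compound 1 to compound 3 (0.18 log units; within the scatter) and stayed within the scatter, so compound 1 cannot be set apart from either compound 2 or compound 3, and a phenyl ring in place of cyclopropyl shows no single direction across these compounds. No available evidence accounts for the separation between compound 2 and compound 3.

The single swap changes both the substituent and the ring number in its name, so the compounds shown cannot separate the exchange of chlorine for nitrile from the change in where the substituent sits. On these data alone, how a phenyl ring carrying an amine or a carboxylic acid, or a longer chain in place of the cyclopropyl group, would read in this assay also remains open.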